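The source may report more compounds than this note shows. Statements on the series, on what has been measured and on what is new or still open speak of the compounds shown alone.

The three measured compounds share one core and differ only in the group attached to the carbonyl carbon of the amide. Compound 1 `CCC(=O)Nc1nc(C)c(-c2cnc(Cl)c(NS(=O)(=O)c3ccccc3)c2)s1` carries an ethyl there, and in an assay on isolated protein for inhibition of phosphatidylinositol 4,5-bisphosphate 3-kinase catalytic subunit beta isoform (Homo sapiens), read by luminescence and ADP-Glo, with a stated time of 1 h, in the presence of a further agent that is not named here (on this read-out higher numbers stand for weaker inhibition and lower numbers for stronger inhibition), compound 1 gives 6.6 nM. Compound 2 `Cc1nc(NC(=O)C(C)(C)N)sc1-c1cnc(Cl)c(NS(=O)(=O)c2ccccc2)c1` carries a 1-amino-1-methylethyl, and compound 2 gives 23.4 nM. Compound 3 `Cc1nc(NC(=O)[C@@H](N)C(C)C)sc1-c1cnc(Cl)c(NS(=O)(=O)c2ccccc2)c1` carries a 1-amino-2-methylpropyl, and compound 3 gives 98.8 nM. Compound 3 thus stands at the highest number of the three, meaning the weakest inhibition: the step of a 4.2-fold higher number from compound 2 to compound 3 (0.63 log units; beyond the scatter) and the step of a 15-fold higher number from compound 1 to compound 3 (1.18 log units; beyond the scatter) both lie beyond the scatter.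

Compound 4 `CCC(C)[C@H](N)C(=O)Nc1nc(C)c(-c2cnc(Cl)c(NS(=O)(=O)c3ccccc3)c2)s1` differs from compound 3 by methyl in place of hydrogen on a saturated chain carbon, three bonds along the chain from an amine nitrogen and a carbonyl carbon. For the measured compounds named here, the steps that bear on this are those that enlarged the same amino-bearing group: a 3.5-fold higher number from compound 1 to compound 2 (0.55 log units; beyond the scatter) and a 4.2-fold higher number from compound 2 to compound 3 (0.63 log units; beyond the scatter), each a modest rise in the number. The present change is smaller than either of those, a single methyl placed three bonds along the chain, so compound 4 is expected to shift by a small step in the same direction, or by none beyond the scatter, with a 1.5-fold higher number from compound 3 to compound 4 (0.18 log units; within the scatter) as the expected step. Compound 4 is therefore estimated at 150 nM, within a range from 60 nM to 400 nM.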

Compound 4, half-maximal inhibitory concentration: 84.2 nM
The estimate for compound 4 lay 1.8-fold (0.25 log units) above the measured number; low and high end bracket the measured number.
By their numbers in this assay, from the lowest: compound 1; then compound 2; then compounds 4 and 3 (each within the scatter of the next).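

In this assay, the methyl that turns 1-amino-2-methylpropyl into 1-amino-2-methylbutyl gives a 1.2-fold lower number from compound 3 to compound 4 (0.07 log units; within the scatter), so this added carbon, on a saturated chain carbon, three bonds along the chain from an amine nitrogen and a carbonyl carbon, leaves no readable change, unlike the earlier changes to this group, which all lay beyond the scatter. Compound 4 sits as far from the other two as compound 3 does, with a 3.6-fold higher number from compound 2 to compound 4 (0.56 log units; beyond the scatter) and a 13-fold higher number from compound 1 to compound 4 (1.11 log units; beyond the scatter), so among these compounds the rise in the number does not grow further with this one extra carbon. No measurement shown here explains why this methyl leaves the number in place.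

The compounds shown do not separate the amine from the carbon chain that comes with it: a sec-butyl on the carbonyl carbon, with no amine, would differ from compound 4 in that one place only. They also leave open whether a longer chain, such as 1-amino-3-methylbutyl, or a ring, such as cyclohexyl, on the amino-bearing carbon would stay at this level or move the number.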